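The source may hold more compounds than are shown below. What is called first, only, known or untested is meant among the compounds shown, and "the series" means these compounds.

Three compounds share the aminophenyl-bearing or trimethoxyphenyl-bearing enone linked to a pyrazole, and a fourth awaits measurement. In a functional assay on PC-3 cells (Homo sapiens) for inhibition, read by sulforhodamine B assay, with a stated time of 48 h (on this read-out lower numbers stand for stronger inhibition of growth and higher numbers for weaker inhibition of growth), compound 1 `COc1cc(-c2cc(/C=C/C(=O)c3ccc(N)cc3)[nH]n2)cc(OC)c1OC` gives 2210 nM, while compound 2 `COc1ccc(-c2cc(/C=C/C(=O)c3ccc(N)cc3)[nH]n2)cc1OC` gives 3710 nM. The change between them is hydrogen in place of methoxy on an aromatic carbon, and it produced a 1.7-fold higher number from compound 1 to compound 2 (0.22 log units; within the scatter). Compound 3 `COc1cc(C(=O)/C=C/c2cc(-c3cc(OC)c(OC)c(OC)c3)n[nH]2)cc(OC)c1OC` gives 1470 nM in this assay; the difference between the core of compound 3 and the core of compound 1 is not broken down here. Compound 4 `COc1ccc(-c2cc(/C=C/C(=O)c3cc(OC)c(OC)c(OC)c3)[nH]n2)cc1OC` differs from compound 3 by hydrogen in place of methoxy on an aromatic carbon, the same change as from compound 1 to compound 2. Since that earlier step was a 1.7-fold higher number from compound 1 to compound 2 (0.22 log units; within the scatter), compound 4 is expected to show a comparable step, a 1.7-fold higher number from compound 3 to compound 4 (0.23 log units; within the scatter), resting on compound 3 at 1470 nM. Compound 4 is therefore estimated at 2500 nM, between 1200 nM and 5500 nM.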

Compound 4, concentration for 50% growth inhibition: 1990 nM
Estimate against measurement, compound 4: 1.3-fold (0.10 log units) above; the measured number falls inside the stated range.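

In this assay, hydrogen in place of methoxy on an aromatic carbon gives a 1.4-fold higher number from compound 3 to compound 4 (0.13 log units; within the scatter). Set beside the earlier step, the change carries from one core to the other without a difference that can be told apart: the same change on two cores in this assay, a 1.7-fold higher number (0.22 log units; within the scatter) from compound 1 to compound 2 and a 1.4-fold higher number (0.13 log units; within the scatter) from compound 3 to compound 4, 1.2-fold (0.09 log units) apart, within the scatter of two such steps. Going by these compounds alone, both steps are small, however, so this shows only that the change has little effect on these two cores; it does not show that the two cores would respond alike to a change with a larger effect, or that the result holds across the wider series.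

The compounds shown leave open what a hydroxyl, an ethoxy or a fluorine on that aromatic carbon would do. They also leave open whether any such group would produce a step beyond the scatter on either core.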